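This account rests on a few compounds, and the source may have more. Where it says the series, first, only, none or still open, it means among the compounds named here.

Measured compounds in an assay on RBL-1 cells with Polyunsaturated fatty acid 5-lipoxygenase (Rattus norvegicus) as the target; a higher number here means a weaker inhibitor, a lower number a stronger inhibitor:
- compound 1, `Cn1ccnc1Cc1ccc2ccccc2c1O`: compound 1 gives 3500 nM
- compound 2, `Oc1c(Cc2ccccn2)ccc2ccccc12`: compound 2 gives 390 nM
- compound 3, `Oc1c(Cc2cccnc2)ccc2ccccc12`: compound 3 gives 230 nM

Compound 3 carries the lowest number of the three in this assay. Its nearest neighbour is compound 2, and the step of a 1.7-fold lower number from compound 2 to compound 3 (0.23 log units; within the scatter) lies within the scatter, so the two cannot be ordered. The furthest is compound 1, and the step of a 15-fold lower number from compound 1 to compound 3 (1.18 log units; beyond the scatter) is clearly beyond the scatter.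

Compound 4, `Oc1c(Cc2ccncc2)ccc2ccccc12`, is the next member to be run. Against compound 3 the change is pyridin-4-yl in place of pyridin-3-yl on a saturated chain carbon bound to an aromatic carbon; the two compounds share every atom and differ only in how the ring is joined.

Going by the values given here, of the measured steps, only one exchanges one pyridyl isomer for another: a 1.7-fold lower number from compound 2 to compound 3 (0.23 log units; within the scatter), within the scatter. The other two steps, a 9.0-fold lower number from compound 1 to compound 2 (0.95 log units; beyond the scatter) and a 15-fold lower number from compound 1 to compound 3 (1.18 log units; beyond the scatter), replace the 1-methyl-1H-imidazol-2-yl ring by a pyridyl ring and therefore say little about a change among pyridyl isomers. On that basis the step from compound 3 to compound 4 is expected to stay within the scatter, with no clear direction, a 1.1-fold higher number from compound 3 to compound 4 (0.05 log units; within the scatter).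

Compound 4 is estimated in this assay at 260 nM, with a range of 90 nM to 800 nM.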

Compound 4, half-maximal inhibitory concentration: 140 nM
Compound 4: middle estimate off by 1.9-fold (0.27 log units), on the high side; the measured number falls inside the stated range.
By their numbers in this assay, from the lowest: compounds 4, 3 and 2 (each within the scatter of the next, the first and the last beyond it); then compound 1.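

In this assay the exchange among pyridyl isomers now gives its first step beyond the scatter, a 2.8-fold lower number from compound 2 to compound 4 (0.44 log units; beyond the scatter), so the point at which the ring is joined to the saturated chain carbon can change the number even with identical atoms. Compound 3 cannot be separated from either neighbour, since a 1.6-fold lower number from compound 3 to compound 4 (0.22 log units; within the scatter) lies within the scatter, as does a 1.7-fold lower number from compound 2 to compound 3 (0.23 log units; within the scatter); the three pyridyl compounds therefore support only the difference between pyridin-2-yl and pyridin-4-yl, not a graded series. The distance from the 1-methyl-1H-imidazol-2-yl compound also extends to a 25-fold lower number from compound 1 to compound 4 (1.40 log units; beyond the scatter), but the data shown offer no explanation for either this step or the difference among the pyridyl isomers.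

Still open, from the compounds shown here alone, is whether a plain phenyl ring or a pyrimidinyl ring at this place would fall with the pyridyl compounds or nearer compound 1. Also open, going by these compounds, is whether the difference between pyridin-2-yl and pyridin-4-yl persists with a longer chain in place of the saturated chain carbon, or with a methoxy group in place of the hydroxyl on the shared core.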